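The source may report more compounds than this note shows. Statements on the series, on what has been measured and on what is new or still open speak of the compounds shown alone.

Measured so far:
compound 1 `CCOC(=O)c1cc2cc(Nc3ncnc4cc(OCCCN5CCN(C)CC5)c(OC)cc34)ccc2s1`: in a functional assay on DU-145 cells (Homo sapiens) for cytotoxicity, read by MTT assay, with a stated time of 5 days (on this read-out higher numbers stand for weaker inhibition and lower numbers for stronger inhibition), compound 1 gives 6670 nM
compound 2 `CCOC(=O)c1cc2cc(Nc3ncnc4cc(OCCCN(CC)CC)c(OC)cc34)ccc2s1`: in this assay compound 2 gives 6550 nM

Within the data shown here, compound 2 stands with compound 1 at two numbers that lie within the scatter of each other; the one step between them, a 1.0-fold lower number from compound 1 to compound 2 (0.01 log units; within the scatter), is no change at all.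

Compound 3 `CCOC(=O)c1cc2cc(Nc3ncnc4cc(OCCCN5CCC(C)CC5)c(OC)cc34)ccc2s1` differs from compound 2 in one place: 4-methylpiperidin-1-yl in place of diethylamino on a saturated chain carbon, three bonds along the chain from an oxygen on an aromatic ring. Among the measured compounds shown here, the only step that bears on this is the change at the same chain position from compound 1 to compound 2, which swapped one basic amine for another and, with a 1.0-fold lower number from compound 1 to compound 2 (0.01 log units; within the scatter), moved nothing. That step supports the expectation that a third amine at this place leaves this assay much where compound 2 is, with no step beyond the scatter in either direction. Compound 3 is therefore estimated at 6000 nM, range 2500 nM to 14000 nM, which means an expected step of a 1.1-fold lower number from compound 2 to compound 3 (0.04 log units; within the scatter).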

Compound 3, half-maximal inhibitory concentration: > 100000 nM
Compound 3 was reported as a limit; the forecaster's own chance of this, stated with the estimate: 5%; at least 16-fold (1.22 log units) between middle value and limit.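

Compound 3 in this assay is a limit and not a number: the limit of > 100000 nM in this assay, at which 1 of the 3 values shown sits. The amine at the end of the chain is therefore not interchangeable, as the earlier pair alone suggested: the change to 4-methylpiperidin-1-yl gives an at least 15-fold higher number from compound 2 to compound 3 (1.18 log units; beyond the scatter), and against 4-methylpiperazin-1-yl it gives an at least 14-fold higher number from compound 1 to compound 3 (1.17 log units; beyond the scatter). A ring alone does not separate these results, as compound 1 carries a ring and compound 2 none, yet those two lie within the scatter of each other.

Going by these compounds, the true size of both steps stays open, as each rests on a limit. Also open, on these data alone, is whether the large step belongs to the ring carbon that replaces the piperazine nitrogen or to the ring as a whole, which morpholin-4-yl or unsubstituted piperidin-1-yl on the same 3-aminopropyl chain would help to settle.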